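Amide-end variation; compound 4 awaits measurement

A few compounds are considered here, and "the series" means these few. Any claim that something is new, unique, unknown or untested is made for them only; others in the source may bear on it.

Three measured compounds share one core and differ only at the group on the amide nitrogen. Compound 1 `O=C(CCC(=O)OCCCCCCSc1ccc([N+](=O)[O-])c2nonc12)Nc1ccccc1` gives 700 nM in an assay on isolated protein for inhibition of glutathione S-transferase Mu 2 (Homo sapiens), with a stated time of 10 min; on this read-out higher numbers stand for weaker inhibition and lower numbers for stronger inhibition. Compound 2 `Cc1ccc(NC(=O)CCC(=O)OCCCCCCSc2ccc([N+](=O)[O-])c3nonc23)cc1` gives 390 nM in this assay, and compound 3 `COc1ccc(NC(=O)CCC(=O)OCCCCCCSc2ccc([N+](=O)[O-])c3nonc23)cc1` gives 130 nM in this assay. Compound 3 has the lowest number of the three: a 5.4-fold lower number from compound 1 to compound 3 (0.73 log units; beyond the scatter) and a 3.0-fold lower number from compound 2 to compound 3 (0.48 log units; beyond the scatter) both lie beyond the scatter, whereas a 1.8-fold lower number from compound 1 to compound 2 (0.25 log units; within the scatter) stays within it.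

Compound 4 `O=C(CCC(=O)OCCCCCCSc1ccc([N+](=O)[O-])c2nonc12)NCCN1CCCC1` is the next compound: 2-(pyrrolidin-1-yl)ethyl in place of 4-methoxyphenyl on an amide-type nitrogen. Among the compounds with values here, all three measured steps concern a substituent on the aromatic ring of an aryl amide; none exchanges that ring for a chain carrying a saturated ring, so no measured step bears directly on this change. The sizes seen so far show how much the amide end alone can move this assay, but give no direction for the present exchange. The expectation is therefore placed near the middle of the measured span with a wide range. This amounts to an expected 3.8-fold higher number from compound 3 to compound 4 (0.59 log units; beyond the scatter). Compound 4 is estimated at 500 nM in this assay, within a range from 100 nM to 2500 nM.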

Compound 4, half-maximal inhibitory concentration: 200 nM
The estimate for compound 4 lay 2.5-fold (0.40 log units) above the measured number, and the stated range covers the measured number.
By their numbers in this assay, from the lowest: compounds 3, 4, 2 and 1 (each within the scatter of the next, the first and the last beyond it).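

In this assay, the aromatic ring on the amide-type nitrogen is not needed to keep the number in the range of the aryl amides: 2-(pyrrolidin-1-yl)ethyl, which carries one five-membered non-aromatic ring with a hetero atom, gives a 1.5-fold higher number from compound 3 to compound 4 (0.19 log units; within the scatter) and a 2.0-fold lower number from compound 2 to compound 4 (0.29 log units; within the scatter), with both steps staying within the scatter. Only the comparison with the unsubstituted phenyl amide lies beyond it, at a 3.5-fold lower number from compound 1 to compound 4 (0.54 log units; beyond the scatter), so among these four compounds this position accepts an aromatic or a saturated ring-bearing group, with compound 1 the one that stands apart from compound 4. Nothing available gives a reason for this result.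

On these data alone, whether the activity of compound 4 depends on the pyrrolidine ring itself remains open, as a piperidine, a morpholine or a simple dimethylamino group on the same ethyl chain would be needed to tell. Also open, as far as these compounds go, is how the number responds to a longer chain between the amide nitrogen and the ring, or to a plain alkyl group with no ring nitrogen at all.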